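Turning One Stereocentre in a Piperidine Amide

A few compounds are considered here, and "the series" means these few. Any claim that something is new, unique, unknown or untested is made for them only; others in the source may bear on it.

- compound 1 `COc1ccccc1-c1csc2cnc(Nc3ccc(NC(=O)C4CCNCC4)cc3)nc12`: 1050 nM
- compound 2 `COc1ccccc1-c1csc2cnc(Nc3ccc(NC(=O)[C@H]4CCCNC4)cc3)nc12`: 440 nM

For the measured compounds named here, in a functional assay on MDA-MB-231 cells (Homo sapiens) for inhibition, read by MTT assay, with a stated time of 72 h (on this read-out lower numbers stand for stronger inhibition and higher numbers for weaker inhibition), compound 2 gives 440 nM, the lower of the two numbers so far. Compound 3 `COc1ccccc1-c1csc2cnc(Nc3ccc(NC(=O)[C@@H]4CCCNC4)cc3)nc12` changes one thing: the two compounds have the same atoms and bonds and differ only in configuration as drawn: 1 of 1 stereo elements differ; a stereocentre at a saturated ring carbon is drawn S in compound 2 and R in compound 3. Going by the values given here, no measured pair yet tests configuration. The nearest guide is the piperidin-3-yl for piperidin-4-yl swap, a 2.4-fold lower number from compound 1 to compound 2 (0.38 log units; beyond the scatter), a modest step that offers a rough size but no direction. A similarly modest step is therefore expected, leaning slightly toward a higher number. The expected change is a 1.4-fold higher number from compound 2 to compound 3 (0.13 log units; within the scatter). In this assay, the estimate for compound 3 is 600 nM, with an expected range of 220 nM to 1600 nM.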

Compound 3, half-maximal inhibitory concentration: 410 nM
Compound 3: the middle estimate sits 1.5-fold (0.17 log units) above what was measured; the measured number falls inside the stated range.
By their numbers in this assay, from the lowest: compounds 3 and 2 (each within the scatter of the next); then compound 1.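

In this assay, swapping S for R at the saturated ring carbon gives a 1.1-fold lower number from compound 2 to compound 3 (0.03 log units; within the scatter), so configuration at this position shows no readable effect. The step from piperidin-4-yl to piperidin-3-yl holds for the R form too, with a 2.6-fold lower number from compound 1 to compound 3 (0.41 log units; beyond the scatter). This comparison tests configuration alone, because nothing else changes: the fact that compounds 2 and 3 differ only in the configuration as drawn

Still open, as far as these compounds go, is whether configuration stays equally unimportant with a pyrrolidine ring in place of the piperidine, or with a methyl group on the piperidine nitrogen.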